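The source may report more compounds than this note shows. Statements on the series, on what has been measured and on what is new or still open speak of the compounds shown alone.

The measured compounds:
Compound 1, `CCN(CC)CCN(C)c1ccc(Nc2cc(NC3CC3)n3ncc(C#N)c3n2)cc1NC(C)=O`, in an ADME assay on cells (Hepatocyte, Rattus norvegicus) for metabolic stability (on this read-out lower numbers stand for slow clearance and higher numbers for fast clearance), gives 27 uL/min.
Compound 2, `CC(=O)Nc1cc(Nc2cc(NC3CC3)n3ncc(C#N)c3n2)ccc1N1CCC[C@@H](N(C)C)C1`, gives < 1 uL/min, which is a limit of the assay rather than a number (the limit of < 1 uL/min in this assay, at which 1 of the 3 values shown sits).
Compound 3, `CCN(CCN)c1ccc(Nc2cc(NC3CC3)n3ncc(C#N)c3n2)cc1NC(C)=O`, gives 2 uL/min.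

Of the two numbers, compound 1 stands highest, and its nearest neighbour is compound 3, at a 14-fold lower number from compound 1 to compound 3 (1.13 log units; beyond the scatter). Compound 4, `CC(=O)Nc1cc(Nc2cc(NC3CC3)n3ncc(C#N)c3n2)ccc1N1CCC[C@H](N)C1`, is not yet measured; it differs from compound 1 in one place: 3-aminopiperidin-1-yl in place of (2-(diethylamino)ethyl)(methyl)amino on an aromatic carbon. Among the measured compounds shown here, two measured steps bear on this change. Replacing the same chain with a group built on a six-membered non-aromatic ring gave an at least 27-fold lower number from compound 1 to compound 2 (1.43 log units; beyond the scatter), and shortening the chain to one carrying a primary amine gave a 14-fold lower number from compound 1 to compound 3 (1.13 log units; beyond the scatter). Both steps are large and point the same way, and compound 4 brings together a ring and a primary amine, so a large step downward in this assay is expected for compound 4, an 18-fold lower number from compound 1 to compound 4 (1.26 log units; beyond the scatter). Compound 4 is estimated at 1.5 uL/min, within 0.5 uL/min to 5 uL/min, with a real chance that only a limit is reported.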

Compound 4, intrinsic clearance in a liver preparation (reported as CLH), per the amount of preparation that the assay uses: < 1 uL/min
Compound 4 gave a limit, no number; the forecaster's own chance of this, stated with the estimate: 35%; at least 1.5-fold (0.17 log units) between middle value and limit.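

Compound 4 gives < 1 uL/min in this assay, which is a limit and not a number: the limit of < 1 uL/min in this assay, at which 2 of the 4 values shown sit. Swapping the (2-(diethylamino)ethyl)(methyl)amino chain for 3-aminopiperidin-1-yl gives an at least 27-fold lower number from compound 1 to compound 4 (1.43 log units; beyond the scatter), so a third group at this position also ends far below the number of the diethylamino chain. Against the open chain, the change gives an at least 2.0-fold lower number from compound 3 to compound 4 (0.30 log units; that floor lies within the scatter), so the ring cannot be told apart from that chain here, and the step between compound 2 and compound 4 cannot be read, as both values are limits.

The compounds shown leave open how far compound 2 and compound 4 truly lie below the limit. They also leave open whether a plain piperidin-1-yl with no amine on the ring would read as low, which would separate the part played by the ring from that of the amine.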